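One Aryl Exchange on a Weakly Cytotoxic Compound

The compounds below may be only part of what the source reports. "The series", "measured", "known", "first", "only" and "open" are said of these compounds alone.

Compound 1, `CNC(=O)c1cc(Oc2ccc(NC(=O)c3cc(-c4ccc(F)cc4)ncn3)cc2F)ccn1`. In a functional assay on PC-3 cells (Homo sapiens) for cytotoxicity, read by MTT assay, with a stated time of 72 h (on this read-out higher numbers stand for weaker inhibition and lower numbers for stronger inhibition), compound 1 reaches only the limit > 100000 nM.
Compound 2, `CNC(=O)c1cc(Oc2ccc(NC(=O)c3cc(-c4ccc(C)cc4)ncn3)cc2)ccn1`. In this assay compound 2 likewise gives only the limit > 100000 nM.
Compound 3, `CNC(=O)c1cc(Oc2ccc(NC(=O)c3nccc(-c4cccc(Cl)c4)n3)cc2)ccn1`. In this assay compound 3 gives 20800 nM.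

For the measured compounds named here, compound 3 is the only one of the three to give a number at all; the two others stop at the limit of > 100000 nM in this assay, at which 2 of the 3 values shown sit, so there is no measured step between any pair, and nothing can be said about how much they differ from one another.

The next compound, compound 4, `CNC(=O)c1cc(Oc2ccc(NC(=O)c3nccc(-c4ccc(C)cc4)n3)cc2)ccn1`, keeps the core of compound 3 and changes one thing: 4-methylphenyl in place of 3-chlorophenyl on an aromatic carbon. Compound 2 carries the same 4-methylphenyl as compound 4, but on a differently built core, and reaches only the limit, so it offers no direct guide.

Going by the values given here, with no measured step to lean on, the expectation is a small weakening beyond the scatter, or none at all. The step of a 1.9-fold higher number from compound 3 to compound 4 (0.28 log units; within the scatter) is expected to be a mild loss. Compound 4 is estimated at about 40000 nM, most likely between 12000 nM and 100000 nM.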

Compound 4, half-maximal inhibitory concentration: 13100 nM
Compound 4: the middle estimate sits 3.1-fold (0.48 log units) above what was measured, within the range that was stated.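

Exchanging 3-chlorophenyl for 4-methylphenyl on this aromatic carbon, next to the ring nitrogen, gives a 1.6-fold lower number from compound 3 to compound 4 (0.20 log units; within the scatter) in this assay, so the two compounds cannot be told apart on this read-out. For the compounds shown here, this is the first step in the set that can be read at all, and it shows that this position can carry either of these two aryl groups while the result remains a measured number. Compound 1 and compound 2, built on a different core, give only a limit and not a number, so neither adds a step to set beside this one: the limit of > 100000 nM in this assay, at which 2 of the 4 values shown sit.

The exchange alters the substituent and its place on the ring together, so this single step cannot separate the effect of swapping chlorine for methyl from that of moving the group around the ring. Both groups compared here are also carbon-only aromatic rings without hydrogen-bond donors or acceptors, which leaves open whether an amine or a carboxylic acid on that ring, or a longer chain in its place, would move the number beyond the scatter.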